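This account rests on a few compounds, and the source may have more. Where it says the series, first, only, none or still open, it means among the compounds named here.

Measured so far:
compound 1 `C=C1C(=O)O[C@H](c2ccc3ccccc3c2)[C@H]1C`: 74%
compound 2 `C=C1C(=O)O[C@H](c2ccccc2)[C@H]1c1ccccc1`: 30%
compound 3 `C=C1C(=O)O[C@H](c2ccc(OC)cc2)[C@H]1c1ccccc1`: 54%

In a functional assay on MIA PaCa-2 cells (Homo sapiens) for cytotoxicity, read by MTT assay, with a stated time of 72 h, tested at 1 uM (on this read-out lower numbers stand for a stronger effect and higher numbers for a weaker effect at the one concentration tested), compound 1 gives 74%, the highest of the three numbers, meaning the weakest effect at the single concentration. Compound 3 gives 54% and compound 2 gives 30%; both gaps from compound 1 lie beyond the scatter. Within the data shown here, the only single-change step measured, a number 24 percentage points higher from compound 2 to compound 3 (beyond the scatter), concerns a methoxy on an aromatic carbon and does not involve the saturated ring carbon.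

Compound 4 `C=C1C(=O)O[C@H](c2ccc3ccccc3c2)[C@H]1c1ccccc1` has not yet been measured. It differs from compound 1 as follows: phenyl in place of methyl on a saturated ring carbon

Among the measured compounds shown here, no measured pair isolates this change, so the step has no direct precedent. What the numbers show is that compound 2 and compound 3, each carrying a phenyl on a saturated ring carbon of the shared core, return lower numbers than compound 1 with methyl there, while also differing from compound 1 elsewhere in the structure. A downward step in this assay is therefore expected, with wide uncertainty. Compound 4 is expected to give 48% (range 25% to 72%). This corresponds to an expected step of a number 26 percentage points lower from compound 1 to compound 4 (beyond the scatter).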

Compound 4, a percentage reported as activity, at one concentration (the size of the read-out at that concentration, not a potency): 29%
Compound 4: the middle estimate sits 19 percentage points above what was measured, and the stated range covers the measured number.
By their numbers in this assay, from the lowest: compounds 4 and 2 (each within the scatter of the next); then compound 3; then compound 1.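

In this assay the pair of compound 1 and compound 4 gives the first direct read on this position, with phenyl in place of methyl on a saturated ring carbon and the rest of the structure unchanged. The result is a number 45 percentage points lower from compound 1 to compound 4 (beyond the scatter) and marks a large move toward the stronger effect at the single concentration tested. Among these compounds, the earlier compounds carried phenyl at this carbon but offered no measured partner with methyl there, so this pair is the first to isolate the change. Compound 4 gives 29% and stays within the scatter of compound 2 at 30% in spite of the one difference elsewhere on the shared core, so that difference has no readable effect on this phenyl-bearing pair.

The compounds shown leave open how a group such as ethyl, benzyl or an aminomethyl chain would read at this carbon, and whether the step from methyl to phenyl holds on other cell lines or at other concentrations. No measurement at hand accounts for the size of this step.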